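Methylation of a phenolic hydroxy on two ester cores

This account rests on a few compounds, and the source may have more. Where it says the series, first, only, none or still open, it means among the compounds named here.

Compound 1 `O=C(/C=C/c1ccc(OCCCCO[N+](=O)[O-])c(O)c1)OCCCCO[N+](=O)[O-]` is a bis-nitrate ester bearing a free hydroxy on the ring. In a functional assay on NCI-H1299 cells (Homo sapiens) for cytotoxicity, read by resazurin assay, with a stated time of 72 h (a higher number here means a weaker inhibitor, a lower number a stronger inhibitor), compound 1 gives > 50000 nM, which is a limit of the assay and not a number. Compound 2 `O=C(/C=C/c1ccc(O)c(O)c1)OCc1c(-c2ccccc2)no[n+]1[O-]` carries a different core; in this assay compound 2 gives > 50000 nM, likewise a limit. The difference between the two cores is not broken down here. Compound 3 `COc1cc(/C=C/C(=O)OCc2c(-c3ccccc3)no[n+]2[O-])ccc1O` in this assay gives 12900 nM. The change from compound 2 to compound 3 is methyl in place of hydrogen on an oxygen on an aromatic ring, and it brought an at least 3.8-fold lower number from compound 2 to compound 3 (0.58 log units; beyond the scatter). Compound 4 `COc1cc(/C=C/C(=O)OCCCCO[N+](=O)[O-])ccc1OCCCCO[N+](=O)[O-]` is not yet measured; it differs from compound 1 by methyl in place of hydrogen on an oxygen on an aromatic ring, the same change set on the core of compound 1, with the place described in identical words. Compound 1 sits at the limit of > 50000 nM in this assay, at which 2 of the 3 values shown sit, so the gain it can show is bounded only on one side. For compound 4 the expected step is an at least 1.6-fold lower number from compound 1 to compound 4 (0.22 log units; that floor lies within the scatter), resting on an at least 3.8-fold lower number from compound 2 to compound 3 (0.58 log units; beyond the scatter) carried over to the other core. Compound 4 is estimated at 30000 nM, with a likely span from 8000 nM to 100000 nM.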

Compound 4, half-maximal inhibitory concentration: > 50000 nM
Compound 4 was reported as a limit; the forecaster's own chance of this, stated with the estimate: 45%; at least 1.6-fold (0.22 log units) between middle value and limit.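

In this assay, for the compounds shown here, compound 4 gives > 50000 nM, a limit of the assay and not a number, and compound 1 stands at the same limit, so no step from hydroxy to methoxy can be read between them. The compounds shown leave open whether this change on the core of compound 1 matches the other core's result, an at least 3.8-fold lower number from compound 2 to compound 3 (0.58 log units; beyond the scatter).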